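The compounds below may be only part of what the source reports. "The series", "measured", "known", "first", "only" and "open" are said of these compounds alone.

Values so far in a functional assay on HL-60 cells (Homo sapiens) for cytotoxicity, read by luminescence and CellTiter-Glo, with a stated time of 3 days; on this read-out higher numbers stand for weaker inhibition and lower numbers for stronger inhibition:
- compound 1 `O=C(Nc1ccc(C(F)(F)F)cc1)c1cc(Br)c(F)cc1O` gives 450 nM
- compound 2 `O=C(Nc1ccc(C(F)(F)F)cc1)c1ccc(Cl)cc1O` gives 630 nM
- compound 3 `O=C(Nc1ccc(C(F)(F)F)cc1)c1ccc(Br)cc1O` gives 360 nM

Compound 3, at 360 nM (the value in question here), lies within the usual scatter of both compound 1 and compound 2, so these three numbers cannot be ranked with confidence.

Compound 4 `O=C(Nc1ccc(C(F)(F)F)cc1)c1ccc(F)cc1O` has not been measured yet. It differs from compound 3 in one place: fluoro in place of bromo on an aromatic carbon (fluoro in place of bromo on an aromatic carbon, meta to a hydroxy group and para to a large group).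

For the measured compounds named here, only one measured step swaps one halogen for another. With bromo in place of chloro on an aromatic carbon, the data show a 1.8-fold lower number from compound 2 to compound 3 (0.24 log units; within the scatter) and no more. Compound 1, which holds both bromo and fluoro, gives 450 nM and so stays within the scatter of compound 3. A large change therefore seems unlikely, although a single small step is thin evidence. Following the direction of that step, a slight lean towards a higher number is expected.

In this assay the expected outcome is a 1.9-fold higher number from compound 3 to compound 4 (0.29 log units; within the scatter) (an estimate, not a measurement). The estimated value for compound 4 is 700 nM (expected range 280 nM to 1800 nM).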

Compound 4, half-maximal inhibitory concentration: 680 nM
Compound 4: the middle estimate sits 1.0-fold (0.01 log units) above what was measured, within the range that was stated.
By their numbers in this assay, from the lowest: compounds 3, 1, 2 and 4 (each within the scatter of the next).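

At this position, on the aromatic carbon para to a large group, this assay can now be compared across fluoro, chloro and bromo, with a 1.9-fold higher number from compound 3 to compound 4 (0.28 log units; within the scatter) for fluoro in place of bromo and a 1.1-fold higher number from compound 2 to compound 4 (0.03 log units; within the scatter) for fluoro in place of chloro. Compound 4 also shows what happens when the bromo on another aromatic carbon of compound 1 gives way to hydrogen, with a 1.5-fold higher number from compound 1 to compound 4 (0.18 log units; within the scatter) as the result. None of these steps leaves the usual scatter, so among these three halogens the choice at this position does not separate the compounds, and no information here explains why the numbers stay so close.

As far as these compounds go, what remains open is whether a group of a different kind on this same carbon, such as an amine, a carboxylic acid or a longer chain like propyl, would move the number beyond the scatter. Also unanswered is what plain hydrogen at this position would give, which would show whether having a halogen here matters at all in this cell-based test.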